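The compounds below may be only part of what the source reports. "The series", "measured", "known", "first", "only" and "open" are said of these compounds alone.

For the measured compounds named here, in a functional assay on DU-145 cells (Homo sapiens) for inhibition (on this read-out higher numbers stand for weaker inhibition and lower numbers for stronger inhibition), compound 2 `Nc1nc(Nc2ccc(Cl)cc2)cc(-c2cc(Cl)ccc2Cl)n1` gives 190 nM, the lower of the two numbers so far, and compound 1 `COc1ccc(Cl)cc1-c1cc(Nc2ccc(Cl)cc2)nc(N)n1` gives 500 nM. Compound 3 `CCOc1ccc(Cl)cc1-c1cc(Nc2ccc(Cl)cc2)nc(N)n1` departs from compound 2 as follows: ethoxy in place of chloro on an aromatic carbon. Going by the values given here, the only measured step bearing on this is a 2.6-fold lower number from compound 1 to compound 2 (0.42 log units; beyond the scatter), a modest change beyond the scatter, for chloro in place of methoxy on an aromatic carbon. Among the compounds with values here, no ethoxy compound has been measured, so methoxy serves as the nearest guide, and a modest rise of similar size is expected in this assay. The estimated move is a 2.6-fold higher number from compound 2 to compound 3 (0.42 log units; beyond the scatter). For compound 3 the expected value is 500 nM, within a range of 200 nM to 1250 nM.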

Compound 3, half-maximal inhibitory concentration: 70 nM
Beside the measured number, compound 3's estimate is 7.1-fold (0.85 log units) above it; measured number below the stated range.
By their numbers in this assay, from the lowest: compound 3; then compound 2; then compound 1.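

At this place, ortho to a large group and para to a chloro group, the oxygen-linked groups do not sit on one side of chloro in this assay: methoxy in compound 1 gives a higher number than chloro in compound 2, yet ethoxy gives a 2.7-fold lower number from compound 2 to compound 3 (0.43 log units; beyond the scatter) and so reverses that order. The added methyl alone gives a 7.1-fold lower number from compound 1 to compound 3 (0.85 log units; beyond the scatter) and is the largest step among these compounds. Nothing measured here accounts for this reversal.

Going by these compounds, whether a longer chain such as propoxy extends the run from methoxy to ethoxy remains open. Also open, on these data alone, is how a branched isopropoxy or a terminal amine on the chain would compare with ethoxy at this place.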